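Methyl on the ring of a tetrahydrofuran amide

A few compounds are considered here, and "the series" means these few. Any claim that something is new, unique, unknown or untested is made for them only; others in the source may bear on it.

Measured compounds and their values:
- compound 1, `Cc1cc(N2CCC(N3CCCC3C)C2)ccc1NC(=O)C1C(C)(C)C1(C)C`: 37.3 nM
- compound 2, `CC1CCCN1C1CCN(c2ccc(NC(=O)C3C(C)(C)C3(C)C)cc2)C1`: 144 nM
- compound 3, `CC1CCCN1C1CCN(c2ccc(NC(=O)C3CCCO3)cc2)C1`: 8.7 nM

All three were tested in an assay on CHO cells for displacement of a labelled ligand from histamine receptor H3 (Macaca mulatta); a higher number here means a weaker inhibitor, a lower number a stronger inhibitor. Compound 2 and compound 3 share everything except the group on the carbonyl carbon: oxolan-2-yl in place of 2,2,3,3-tetramethylcyclopropyl on a carbonyl carbon. That exchange made a large step, a 17-fold lower number from compound 2 to compound 3 (1.22 log units; beyond the scatter), and in this assay compound 3 gives the lowest number of the three.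

Compound 1 differs from compound 2 only by one small change: methyl in place of hydrogen on an aromatic carbon. Here the step was a 3.9-fold lower number from compound 2 to compound 1 (0.59 log units; beyond the scatter), modest but beyond the scatter.

The unmeasured compound 4, `Cc1cc(N2CCC(N3CCCC3C)C2)ccc1NC(=O)C1CCCO1`, takes compound 3 as its core and applies the same kind of change: methyl in place of hydrogen on an aromatic carbon. The surroundings of the new methyl are not described in the same words for the two pairs: in compound 1 it sits ortho to a large group, while in compound 4 it sits ortho to a ((oxolan-2-yl)carbonyl)amino group. The steps are therefore of the same kind rather than the same.

For compound 4 in this assay the expected step is a 2.5-fold lower number from compound 3 to compound 4 (0.40 log units; beyond the scatter), set beside the earlier one because the measured pair gave a 3.9-fold lower number from compound 2 to compound 1 (0.59 log units; beyond the scatter) and compound 3 starts from 8.7 nM. Compound 4 is expected to give about 3.5 nM, with the likely range from 1.5 nM to 9 nM.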

Compound 4, inhibition constant: 7.34 nM
Beside the measured number, compound 4's estimate is 2.1-fold (0.32 log units) below it; the measured number falls inside the stated range.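

In this assay, for the compounds shown here, the methyl that counted on the core of compound 2 made no step that can be told from the scatter on the core of compound 3, a 1.2-fold lower number from compound 3 to compound 4 (0.07 log units; within the scatter), so the size of the earlier step did not carry over to the oxolan-2-yl amide: the same change on two cores in this assay, a 3.9-fold lower number (0.59 log units; beyond the scatter) from compound 2 to compound 1 and a 1.2-fold lower number (0.07 log units; within the scatter) from compound 3 to compound 4, 3.3-fold (0.51 log units) apart, beyond the scatter of two such steps. The same two cores can be read the other way: with the methyl in place, oxolan-2-yl in place of 2,2,3,3-tetramethylcyclopropyl on the carbonyl carbon still gave a 5.1-fold lower number from compound 1 to compound 4 (0.71 log units; beyond the scatter), the same direction as before but a smaller step: the same change on two cores in this assay, a 17-fold lower number (1.22 log units; beyond the scatter) from compound 2 to compound 3 and a 5.1-fold lower number (0.71 log units; beyond the scatter) from compound 1 to compound 4, 3.3-fold (0.51 log units) apart, beyond the scatter of two such steps. Going by these compounds alone, this shows that a step measured on one core cannot simply be added to another, though it rests on only two cores and one methyl position, and it gives no reason for the difference and no rule for other amides.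

As far as these compounds go, what stays open is whether a different group at this place on the aromatic ring, such as chlorine, methoxy or ethyl, would also depend on the amide group. From the compounds shown here alone, it is also open how the methyl would behave with a third group on the carbonyl carbon, such as cyclopropyl or oxan-4-yl.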